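A few compounds are considered here, and "the series" means these few. Any claim that something is new, unique, unknown or untested is made for them only; others in the source may bear on it.

Of the compounds shown here, three share a core and have been measured in a functional assay on SF-539 cells (Homo sapiens) for cytotoxicity, read by sulforhodamine B assay, with a stated time of 48 h, tested at 100 nM; on this read-out higher numbers stand for a weaker effect at the one concentration tested and lower numbers for a stronger effect. Compound 1 `COc1cc(C)cc(-c2c(-c3ccnc(-c4ccc(C(C)=O)cc4)c3)cnn2CC#N)c1` carries an acetyl group on one outer ring; in this assay compound 1 gives 92%, the highest of the three numbers. Compound 2 `COc1cc(C)cc(-c2nn(CC#N)cc2-c2ccnc(-c3ccc(N(C)C)cc3)c2)c1` carries a dimethylamino group instead and gives -31%. Compound 3 `Cc1cc(O)cc(-c2nn(CC#N)cc2-c2ccnc(-c3ccc(N(C)C)cc3)c2)c1` gives 91%, within the scatter of compound 1. For the measured compounds named here, the only single-point step measured so far runs a number 122 percentage points higher from compound 2 to compound 3 (beyond the scatter).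

Compound 4 `COc1cc(C)cc(-c2c(-c3ccnc(-c4ccc(N(C)C)cc4)c3)cnn2CC#N)c1` has not yet been measured. It is reached from compound 1 by one change: dimethylamino in place of acetyl on an aromatic carbon. Going by the values given here, no measured step covers this exact exchange, so the expectation rests on what the measured values show. Compound 1, with acetyl, gives a very weak effect, while compound 2, which also carries a dimethylamino group but differs from compound 4 elsewhere in the core, gives a far lower number and thus a strong effect. The step from compound 2 to compound 3 shows that other parts of the structure can swing the read-out widely, so the estimate is uncertain. On balance, compound 4 is expected to move toward a stronger effect, a step estimated as a number 57 percentage points lower from compound 1 to compound 4 (beyond the scatter). The estimated value for compound 4 is 35%, with a range from -35% to 95%.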

Compound 4, a percentage reported as activity, at one concentration (the size of the read-out at that concentration, not a potency): -29%
Compound 4: middle estimate off by 64 percentage points, on the high side; measured number inside the range.
By their numbers in this assay, from the lowest: compounds 2 and 4 (each within the scatter of the next); then compounds 3 and 1 (each within the scatter of the next).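

In this assay, exchanging acetyl for dimethylamino on the aromatic carbon para to a large group, with the rest of the molecule unchanged, gives a number 121 percentage points lower from compound 1 to compound 4 (beyond the scatter), so this single position can by itself separate a weak effect from a strong one at the concentration tested. The two groups have the same heavy-atom count and the same hydrogen-bond donor and acceptor counts, and neither carries a net charge, so those counts do not separate them; the visible differences are nitrogen in place of oxygen and the loss of the double bond outside the aromatic rings. No measurement shown explains why this exchange has so large an effect.

The compounds shown leave open whether the strong effect needs dimethylamino itself or would also appear with a simple primary amine, a methoxy group or a ring amine such as morpholine at the same place. They also leave open whether acetyl would have the same outcome on the hydroxy-bearing core of compound 3, and, with only one concentration tested, how the compounds would compare at other concentrations.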